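The source may hold more compounds than are shown below. What is called first, only, known or untested is meant among the compounds shown, and "the series" means these compounds.

Compounds measured so far in an assay on isolated protein for binding affinity to adenosine receptor A1 (Bos taurus); on this read-out lower numbers stand for stronger inhibition and higher numbers for weaker inhibition:

compound 1 `CCCCCCNc1nc(-c2ccccc2)nc2c1nnn2Cc1ccccc1` — 13200000 nM
compound 2 `COc1ccc(C(=O)Nc2nc(-c3ccccc3)nc3c2nnn3Cc2ccccc2F)cc1` — 21900000 nM
compound 3 `CCCCCCNc1nc(-c2ccccc2)nc2c1nnn2Cc1ccccc1Cl` — 31000000 nM

All three compounds share one core and give very high numbers in this assay, meaning only very weak binding. Compound 1 has the lowest of the three numbers. Its gap to compound 2 is within the usual scatter of this kind of measurement, so no order between these two can be claimed. Compound 3 stands further away: a 2.3-fold higher number from compound 1 to compound 3 (0.37 log units; beyond the scatter), a step that comes from chloro in place of hydrogen on an aromatic carbon.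

Compound 4 `CCCCNc1nc(-c2ccccc2)nc2c1nnn2Cc1ccccc1` has not yet been measured. It differs from compound 1 by hydrogen in place of ethyl on a saturated chain carbon, four bonds along the chain from a nitrogen on an aromatic ring. Within the data shown here, none of the measured steps touches this chain; the one step that is known, from compound 1 to compound 3, changes an aromatic substituent instead, so no measured step bears directly on this change. With nothing pointing in either direction, no step beyond the scatter is expected in this assay; the estimate for compound 4 is 13000000 nM, with a range from 4000000 nM to 40000000 nM, which means an expected step of a 1.0-fold lower number from compound 1 to compound 4 (0.01 log units; within the scatter).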

Compound 4, inhibition constant: 11000000 nM
Estimate against measurement, compound 4: 1.2-fold (0.07 log units) above; the range from low to high includes it.
By their numbers in this assay, from the lowest: compounds 4, 1, 2 and 3 (each within the scatter of the next, the first and the last beyond it).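

In this assay, the change on the saturated chain gives a 1.2-fold lower number from compound 1 to compound 4 (0.08 log units; within the scatter), so no difference can be claimed between these two compounds, and both still bind only very weakly. Among these compounds, until now the only step available was on an aromatic carbon, a 2.3-fold higher number from compound 1 to compound 3 (0.37 log units; beyond the scatter); this one adds the first reading on the chain, where losing ethyl in this place does not move the number beyond the usual scatter. Nothing measured here explains this outcome, and no separate data bear on it.

As far as these compounds go, a single step on one chain says little about the chain as a whole, so what a longer chain would do remains open. So does the effect of an amine or a carboxylic acid on this chain, and whether either would bring binding that is less weak.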